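Swapping ethyl for oxolan-3-yl on an amide carbonyl

The compounds below may be only part of what the source reports. "The series", "measured", "known", "first", "only" and "open" are said of these compounds alone.

Of the compounds shown here, three sharing one core have been measured in an ADME assay on the whole organism (Rattus norvegicus, strain Wistar Han) for pharmacokinetics; on this read-out higher numbers stand for fast clearance and lower numbers for slow clearance. Compound 1 `CCn1c(-c2cnc(C)nc2)nc2c(N[C@H]3CCN(C(=O)c4cocn4)C3)ncnc21` gives 13 mL/min/kg. Compound 2 `CCC(=O)N1CC[C@H](Oc2ncnc3c2nc(-c2cnc(C)nc2)n3CC)C1` gives 12 mL/min/kg. Compound 3 `CCn1c(-c2ccc(C(F)(F)F)nc2)nc2c(O[C@H]3CCN(C(=O)C4CC4)C3)ncnc21` gives 15 mL/min/kg. The three numbers sit close together: the gap from compound 2 to compound 1 and the gap from compound 2 to compound 3 both fall within the usual scatter of repeated measurements, so none of the three can be set apart from the others on this read-out.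

The step of interest starts from compound 2 and leads to compound 4 `CCn1c(-c2cnc(C)nc2)nc2c(O[C@H]3CCN(C(=O)C4CCOC4)C3)ncnc21`, which has not yet been measured. The change is small and sits on the amide carbonyl carbon: oxolan-3-yl in place of ethyl on a carbonyl carbon. Because compound 2 gives 12 mL/min/kg and the step from compound 2 to compound 4 is a single substitution on a side group, the expected outcome is a number in the same neighbourhood, with no step beyond the scatter in either direction. Compound 4 is therefore estimated at 12 mL/min/kg, with a range from 6 mL/min/kg to 25 mL/min/kg, which means an expected step of no change at the digits printed from compound 2 to compound 4 (within the scatter).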

Compound 4, clearance: 6.2 mL/min/kg
For compound 4 the middle estimate is 1.9-fold (0.29 log units) above the measured one; low and high end bracket the measured number.
By their numbers in this assay, from the lowest: compounds 4, 2, 1 and 3 (each within the scatter of the next, the first and the last beyond it).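

For the compounds shown here, this is the first pair in the set that differs in one place only, so the group on the amide carbonyl can be read on its own. In this assay, oxolan-3-yl in place of ethyl on this carbonyl carbon gives a 1.9-fold lower number from compound 2 to compound 4 (0.29 log units; within the scatter) and thus no step beyond the usual scatter, even though the change raises the group from 2 to 5 heavy atoms and adds a non-aromatic ring and a hydrogen-bond acceptor. For this one pair, then, a clearly larger group on the carbonyl carbon leaves clearance within the scatter, while nothing shown offers an explanation for the number.

The compounds shown cannot separate the effect of the ring from that of its oxygen, and cyclopentyl, an all-carbon ring, on the same carbonyl carbon would be the comparison that speaks to this. Going by these compounds, how an amine or a carboxylic acid carried on this carbonyl carbon would read also remains open, as a single substitution says little about the range of groups this position can carry.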